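Nitrobenzylamine series: methyl in place of methylsulfonyl

The compounds below may be only part of what the source reports. "The series", "measured", "known", "first", "only" and "open" are said of these compounds alone.

Measured compounds:
compound 1, `O=[N+]([O-])c1ccccc1CNc1cc(C(F)(F)F)cc2[nH]ncc12` — > 20000 nM
compound 2, `CS(=O)(=O)c1ccc(CNc2cc(C(F)(F)F)cc3[nH]ncc23)c([N+](=O)O)c1` — > 20000 nM

In a functional assay on Jurkat cells (Homo sapiens) for inhibition, read by MTT assay, with a stated time of 24 h (on this read-out lower numbers stand for stronger inhibition and higher numbers for weaker inhibition), compound 1 gives > 20000 nM, which is a limit of the assay and not a number. In this assay compound 2 gives > 20000 nM, again a limit rather than a measured number. Compound 2 therefore stands at the limit of > 20000 nM in this assay, at which 2 of the 2 values shown sit, and no order between compound 1 and compound 2 can be read from these two results.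

Compound 3, `Cc1ccc(CNc2cc(C(F)(F)F)cc3[nH]ncc23)c([N+](=O)O)c1`, remains to be measured in this assay. Against compound 2 the change is methyl in place of methylsulfonyl on an aromatic carbon. Among the measured compounds shown here, no step between two measured compounds is available, so the data hold no measured precedent for what this exchange does to inhibition; any expectation rests on the two limits alone.

With both measured compounds sitting at the assay limit, the expected step is a step that the limit leaves unreadable from compound 2 to compound 3, that is none beyond the scatter, and a limit rather than a number is again the likelier report. Compound 3 is estimated at 30000 nM, with a range from 8000 nM to 100000 nM.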

Compound 3, half-maximal inhibitory concentration: 7250 nM
The estimate for compound 3 lay 4.1-fold (0.62 log units) above the measured number; measured number below the stated range.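

In this assay the series now holds its first step that can be read, and it falls on the aromatic carbon para to a large group: methyl in place of methylsulfonyl gives an at least 2.7-fold lower number from compound 2 to compound 3 (0.44 log units; beyond the scatter). The two earlier results could not show that this carbon matters at all, whereas this pair, which differs in this one place only, shows that the read-out responds to the group carried there and that a number inside the measurable range can be reached on the shared core. The step can be stated only as a lower bound, and its true size stays unknown because compound 2 sits at a limit: the limit of > 20000 nM in this assay, at which 2 of the 3 values shown sit.

Compound 1, which carries neither group on this carbon, gives > 20000 nM, a limit of the assay and not a number, so what methyl adds over the bare carbon has no size here. As far as these compounds go, how an ethyl group, a methoxy group or an amine on the same carbon would read in this assay stays open, as does whether a longer chain would continue the direction seen with methyl.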